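The compounds below may be only part of what the source reports. "The series", "measured", "known", "first", "only" and "open" are said of these compounds alone.

Measured compounds:
compound 1 `CCC(CC)Cn1c(Cc2cc(OC)c(OC)c(OC)c2)nc2c(N)ncnc21` gives 158000 nM in a functional assay on MCF7 cells (Homo sapiens) for antiproliferative activity; a higher number here means a weaker inhibitor, a lower number a stronger inhibitor;
compound 2 `CCCCn1c(Cc2c(Br)c(OC)c(OC)c(OC)c2Br)nc2c(N)ncnc21` gives 30200 nM in this assay;
compound 3 `COc1cc(Cc2nc3c(N)ncnc3n2CC2CCCCC2)cc(OC)c1OC` gives 39800 nM in this assay.

Compound 3 stands second highest of the three numbers. Its nearest neighbour is compound 2, whose value lies within the scatter of it; compound 2 differs from compound 3 in more than one place, so the two values are only set side by side. Its furthest neighbour is compound 1, reached by a 4.0-fold lower number from compound 1 to compound 3 (0.60 log units; beyond the scatter).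

Compound 4 `CC/C=C/Cn1c(Cc2cc(OC)c(OC)c(OC)c2)nc2c(N)ncnc21` is not yet measured. It differs from compound 3 by but-1-en-1-yl in place of cyclohexyl on a saturated chain carbon bound to an aromatic nitrogen; cut one bond further out, the same difference reads cyclohexylmethyl to pent-2-en-1-yl. For the measured compounds named here, the only measured step at this position is the one from compound 1 to compound 3, a modest gain with the ring entering. Compound 4 has no ring and a shorter chain, so this step gives only a rough guide, and a small shift towards a higher number is expected, a 1.5-fold higher number from compound 3 to compound 4 (0.18 log units; within the scatter). Compound 4 is therefore estimated at 60000 nM, with a range from 20000 nM to 200000 nM.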

Compound 4, half-maximal inhibitory concentration: 46800 nM
Compound 4: middle estimate off by 1.3-fold (0.11 log units), on the high side, and the stated range covers the measured number.
By their numbers in this assay, from the lowest: compounds 2, 3 and 4 (each within the scatter of the next); then compound 1.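

In this assay, but-1-en-1-yl in place of cyclohexyl gives a 1.2-fold higher number from compound 3 to compound 4 (0.07 log units; within the scatter), so on this saturated chain carbon bound to an aromatic nitrogen, the two groups cannot be told apart, although one has a six-membered ring and the other has none. The same open group in place of pentan-3-yl gives a 3.4-fold lower number from compound 1 to compound 4 (0.53 log units; beyond the scatter), which shows that, among these compounds, a better number than that of compound 1 does not require a ring. Nothing available explains these differences.

The compounds shown leave open whether the double bond of but-1-en-1-yl matters, since no saturated butyl group stands at this place on the same core. They also leave open how a longer chain, a phenyl ring or an amine would read here.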